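A few compounds are considered here, and "the series" means these few. Any claim that something is new, unique, unknown or untested is made for them only; others in the source may bear on it.

Working notes on the series. Compound 2 `COc1ccc([C@@H]2CC(=O)c3c(O)cc(OCc4cn(C)nn4)cc3O2)cc1O` shares its core with compound 1 `COc1ccc([C@@H]2CC(=O)c3c(O)cc(OCc4cn(Cc5ccccc5Cl)nn4)cc3O2)cc1O`; the two differ only at the saturated chain carbon bound to an aromatic nitrogen. In a functional assay on RAW264.7 cells (Mus musculus) for inhibition, read by Griess assay, with stated times of 2 h and 24 h (on this read-out higher numbers stand for weaker inhibition and lower numbers for stronger inhibition), compound 1 gives 6140 nM. In this assay, among the compounds with values here, compound 2 gives 15200 nM, the highest of the two numbers at hand, and the one step measured within the pair, a 2.5-fold higher number from compound 1 to compound 2 (0.39 log units; beyond the scatter), is modest but beyond the scatter. Compound 3 `COc1ccc([C@@H]2CC(=O)c3c(O)cc(OCc4cn(Cc5ccc(C)cc5)nn4)cc3O2)cc1O` is the next member: its change from compound 2 reads (4-methylphenyl in place of hydrogen on a saturated chain carbon bound to an aromatic nitrogen), so methyl becomes 4-methylbenzyl at the same place where compound 1 carries its 2-chlorobenzyl. Within the data shown here, only that single step bears on it; it shows that removing an aryl from this chain carbon raised the number modestly, and restoring an aryl of similar size is expected to reverse that, so for compound 3 a lowering of about a 2.2-fold lower number from compound 2 to compound 3 (0.34 log units; beyond the scatter) is estimated. Whether the methyl on the ring adds anything cannot be read from the two compounds measured. For compound 3 in this assay the expected value is therefore 7000 nM, with a range from 3000 nM to 16000 nM.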

Compound 3, half-maximal inhibitory concentration: 16800 nM
Compound 3: middle estimate off by 2.4-fold (0.38 log units), on the low side, outside the stated range (above it).
By their numbers in this assay, from the lowest: compound 1; then compounds 2 and 3 (each within the scatter of the next).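

In this assay, 4-methylphenyl in place of hydrogen on a saturated chain carbon bound to an aromatic nitrogen leaves the number within the scatter (a 1.1-fold higher number from compound 2 to compound 3 (0.04 log units; within the scatter)), so an aryl ring at this place does not by itself lower the number. The earlier step could be read as a gain from any aryl ring, but 4-methylphenyl in place of 2-chlorophenyl at the same place gives a modest step beyond the scatter (a 2.7-fold higher number from compound 1 to compound 3 (0.44 log units; beyond the scatter)), and among these three compounds only compound 1, with its 2-chlorophenyl, stands apart. The data at hand offer no measurement that would account for this difference between the two aryl groups.

The two aryl groups differ both in the substituent and in where it sits on the ring, so these compounds cannot separate the two, and 4-chlorophenyl or 2-methylphenyl at this place would be needed to do so. On these data alone, how a group of another kind, such as an amine or a carboxylic acid, would read at this place also remains open.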